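The source may hold more compounds than are shown below. What is called first, only, known or untested is meant among the compounds shown, and "the series" means these compounds.

Three compounds built on the same core, differing only in the group attached to an amide-type nitrogen, have been tested in a functional assay on RT-112 cells (Homo sapiens) for antiproliferative activity, read by MTT assay, with a stated time of 72 h; on this read-out lower numbers stand for stronger inhibition of growth and higher numbers for weaker inhibition of growth. Compound 1 `COc1cc(Nc2ncnc3c(NC(=O)Nc4cc(Cl)cc(Cl)c4)cccc23)cc(OC)c1` carries a 3,5-dichlorophenyl group there and gives 30.2 nM, the lowest number of the three and therefore the strongest growth inhibitor among them. Compound 2 `COc1cc(Nc2ncnc3c(NC(=O)Nc4ccc(F)cc4C(F)(F)F)cccc23)cc(OC)c1` gives 2970 nM, and compound 3 `COc1cc(Nc2ncnc3c(NC(=O)Nc4cc(C)cc(C)c4)cccc23)cc(OC)c1` gives 10100 nM. Both exchanges away from compound 1 cost potency heavily: a 98-fold higher number from compound 1 to compound 2 (1.99 log units; beyond the scatter) and a 330-fold higher number from compound 1 to compound 3 (2.52 log units; beyond the scatter), while a 3.4-fold higher number from compound 2 to compound 3 (0.53 log units; beyond the scatter) separates the two weaker compounds from each other.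

Compound 4 `COc1cc(Nc2ncnc3c(NC(=O)Nc4cccc(C(F)(F)F)c4F)cccc23)cc(OC)c1` is the next step from compound 1. The change is 2-fluoro-3-(trifluoromethyl)phenyl in place of 3,5-dichlorophenyl on an amide-type nitrogen. The two measured steps away from compound 1 both replaced the 3,5-dichlorophenyl group and both raised the number by a large amount; the step to compound 2, which likewise brought in fluorine and a trifluoromethyl group, is the closer guide. Among the measured compounds shown here, a large rise is therefore expected for compound 4, toward weaker inhibition of growth, though its exact size cannot be fixed closely, as no other analogue carrying fluorine was measured. Compound 4 is estimated at 1500 nM, with a likely range from 300 nM to 8000 nM, which would mean a 50-fold higher number from compound 1 to compound 4 (1.70 log units; beyond the scatter).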

Compound 4, concentration for 50% growth inhibition: 471 nM
Compound 4: the middle estimate sits 3.2-fold (0.50 log units) above what was measured, and the stated range covers the measured number.
By their numbers in this assay, from the lowest: compound 1; then compound 4; then compound 2; then compound 3.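

In this assay the two groups that bring in fluorine and trifluoromethyl hold the same atoms and differ only in the numbers of their names, yet the exchange between them gives a 6.3-fold lower number from compound 2 to compound 4 (0.80 log units; beyond the scatter) and so shows that, at this amide-type nitrogen, the arrangement on the ring counts and not only the atoms it carries. The new group also does far better than the 3,5-dimethylphenyl group, with a 21-fold lower number from compound 3 to compound 4 (1.33 log units; beyond the scatter) while it still falls short of the 3,5-dichlorophenyl group, with a 16-fold higher number from compound 1 to compound 4 (1.19 log units; beyond the scatter) and so none of the three replacements shown reaches the growth inhibition seen with the 3,5-dichlorophenyl group. Nothing available explains why the four groups fall in this order.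

As far as these compounds go, what a 3,5-difluorophenyl group, or a phenyl ring bearing an amine or a carboxylic acid, would do at this nitrogen remains open. From the compounds shown here alone, it also remains open whether the 3,5-dichlorophenyl group would keep its lead on cells other than those of this single line.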